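From 4-hydroxyphenyl to 3-aminophenyl on the carbonyl carbon

The source may hold more compounds than are shown below. What is called first, only, known or untested is meant among the compounds shown, and "the series" means these compounds.

Compound 1 `O=C(/C=C/c1ccc2c(c1)B(O)OC2)c1cccnc1` gives 20500 nM in a functional assay on HCT-116 cells (Homo sapiens) for cytotoxicity, read by MTT assay, with a stated time of 48 h; on this read-out lower numbers stand for stronger inhibition and higher numbers for weaker inhibition.
Compound 2 `Cn1cccc1C(=O)/C=C/c1ccc2c(c1)B(O)OC2` gives > 100000 nM in this assay, which is a limit of the assay and not a number.
Compound 3 `O=C(/C=C/c1ccc2c(c1)B(O)OC2)c1ccc(O)cc1` gives 24100 nM in this assay.

Compound 3 holds the highest of the two numbers, and its nearest neighbour is compound 1, with a 1.2-fold higher number from compound 1 to compound 3 (0.07 log units; within the scatter). Compound 4 `Nc1cccc(C(=O)/C=C/c2ccc3c(c2)B(O)OC3)c1` differs from compound 3 by 3-aminophenyl in place of 4-hydroxyphenyl on a carbonyl carbon. The step that bears most on it is the earlier swap at the same carbonyl carbon, a 1.2-fold higher number from compound 1 to compound 3 (0.07 log units; within the scatter), which changed little; the steps of an at least 4.8-fold higher number from compound 1 to compound 2 (0.68 log units; beyond the scatter) and an at least 4.1-fold lower number from compound 2 to compound 3 (0.61 log units; beyond the scatter) were larger but rest on (the limit of > 100000 nM in this assay, at which 1 of the 3 values shown sits). A step no larger than the scatter is therefore expected in this assay, namely a 1.0-fold lower number from compound 3 to compound 4 (0.00 log units; within the scatter). Compound 4 is estimated at 24000 nM, within 10000 nM to 60000 nM.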

Compound 4, half-maximal inhibitory concentration: 4500 nM
The estimate for compound 4 lay 5.3-fold (0.73 log units) above the measured number; the measured number lies below the stated range.
By their numbers in this assay, from the lowest: compound 4; then compounds 1 and 3 (each within the scatter of the next). At a limit, above all of these: compound 2.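

Until now, swapping groups at this carbonyl carbon had lowered no number beyond the scatter, but 3-aminophenyl does so against both earlier aryl groups, with a 5.4-fold lower number from compound 3 to compound 4 (0.73 log units; beyond the scatter) and a 4.6-fold lower number from compound 1 to compound 4 (0.66 log units; beyond the scatter). So this position can respond to a change of ring substituent in this assay, and not only with a loss. The widest step, an at least 22-fold lower number from compound 2 to compound 4 (1.34 log units; beyond the scatter), gives only a bound, as it rests on a limit and not a number: the limit of > 100000 nM in this assay, at which 1 of the 4 values shown sits.

Still open, on these data alone, is whether the amine itself or its place on the ring carries the gain. 3-Hydroxyphenyl and 4-aminophenyl at this carbon would tell these apart.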